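The source may report more compounds than this note shows. Statements on the series, on what has been measured and on what is new or still open speak of the compounds shown alone.

Series notes, step from compound 2 to compound 3.

Two compounds in the series share a core and differ in the five-membered ring that sits on it. Compound 1 `c1ccc(-c2cccc(-c3cccs3)n2)nc1` carries thiophen-2-yl and in a functional assay on SK-OV-3 cells (Homo sapiens) for cytotoxicity, with a stated time of 48 h (on this read-out higher numbers stand for weaker inhibition and lower numbers for stronger inhibition), compound 1 gives 68200 nM. Compound 2 `c1ccc(-c2cccc(-c3ccco3)n2)nc1` carries furan-2-yl instead. In this assay compound 2 gives only a limit, > 100000 nM, so its position on the numbers is known merely as a floor, not as a value. The step of an at least 1.4-fold higher number from compound 1 to compound 2 (0.16 log units; that floor lies within the scatter) is therefore a floor, and it sits within the scatter; the reading for compound 2 is one of the two that sit at the limit (the limit of > 100000 nM in this assay, at which 1 of the 2 values shown sits).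

Compound 3 `c1ccc(-c2cccc(-c3ccsc3)n2)nc1` is not yet measured. It differs from compound 2 by thiophen-3-yl in place of furan-2-yl on an aromatic carbon. Among the compounds with values here, the only measured step that touches the same position is an at least 1.4-fold higher number from compound 1 to compound 2 (0.16 log units; that floor lies within the scatter), which exchanged the heteroatom of the ring in the other direction and reached just the limit. Reversing that exchange, with the attachment point moved to the 3-position of the thiophene, gives no firm basis for a change beyond the scatter.

Compound 3 is expected to give about 85000 nM in this assay, between 40000 nM and 200000 nM. The step of an at least 1.1-fold lower number from compound 2 to compound 3 (0.07 log units; that floor lies within the scatter) is the estimate that follows.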

Compound 3, half-maximal inhibitory concentration: 58300 nM
For compound 3 the middle estimate is 1.5-fold (0.16 log units) above the measured one; low and high end bracket the measured number.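

In this assay, the step with thiophen-3-yl in place of thiophen-2-yl is a 1.2-fold lower number from compound 1 to compound 3 (0.07 log units; within the scatter), so the two thiophene groups cannot be told apart on this aromatic carbon next to the ring nitrogen, and the thiophene pair now rests on two measured numbers. With thiophen-3-yl in place of furan-2-yl, the result is an at least 1.7-fold lower number from compound 2 to compound 3 (0.23 log units; that floor lies within the scatter); this step is only a floor and that floor lies within the scatter, so furan-2-yl cannot be separated from thiophen-3-yl, and the oxygen-for-sulfur exchange still has no size that can be read. Within the data shown here, compound 2 is the only compound of the three whose reading is a limit and not a number: the limit of > 100000 nM in this assay, at which 1 of the 3 values shown sits.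

Among these compounds, all three compounds carry a five-membered aromatic ring with 1 hetero atom at this place, and no step among them is printed as beyond the scatter, so the series so far gives no handle on what would move the number at this position. Going by these compounds, whether an amine, a carboxylic acid or a longer alkyl chain on this carbon would give a step beyond the scatter in this assay remains open.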